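Replacing 2-methylpyridin-3-yl with 1,3-benzothiazol-5-yl in the series

The source may hold more compounds than are shown below. What is called first, only, known or untested is meant among the compounds shown, and "the series" means these compounds.

Among the compounds with values here, in a physicochemical assay for solubility, in phosphate buffer, at pH 7.4 (on this read-out lower numbers stand for lower solubility and higher numbers for higher solubility), compound 3 `Cc1ncccc1-c1nccnc1OC1CN(c2ccc3ccccc3n2)C1` gives 253000 nM as the only true number among the measured compounds. Compound 1 `Cc1ccc(-c2nccnc2OC2CN(c3ccc4ccccc4n3)C2)cc1` gives < 1000 nM and that is a limit of the assay. Compound 2 `N#Cc1ccc(-c2nccnc2OC2CN(c3ccc4ccccc4n3)C2)cc1` gives < 1000 nM and that too is a limit. The step that the two limits leave unreadable from compound 1 to compound 2 therefore adds nothing on size.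

Compound 4 `c1ccc2nc(N3CC(Oc4nccnc4-c4ccc5scnc5c4)C3)ccc2c1` carries 1,3-benzothiazol-5-yl in place of 2-methylpyridin-3-yl on an aromatic carbon of the shared core, with the counted difference 1,3-benzothiazol-5-yl in place of 2-methylpyridin-3-yl on an aromatic carbon as the whole change.

Within the data shown here, two measured steps bear on it, both large: an at least 250-fold higher number from compound 1 to compound 3 (2.40 log units; beyond the scatter) and an at least 250-fold higher number from compound 2 to compound 3 (2.40 log units; beyond the scatter) both bring in 2-methylpyridin-3-yl. The entering group holds a six-membered aromatic ring of carbon only, as do 4-methylphenyl and 4-cyanophenyl. Among the measured compounds shown here, a large step to lower numbers in this assay is therefore expected, estimated as a 250-fold lower number from compound 3 to compound 4 (2.40 log units; beyond the scatter) and read from no measured pair. For compound 4 the estimated value is 1000 nM with an expected range from 300 nM to 6000 nM and a report as a limit would be no surprise.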

Compound 4, solubility: < 1000 nM
Compound 4 gave a limit, no number (the forecaster's own chance of this, stated with the estimate: 60%); the middle value lies on the limit itself.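

In this assay, the change at this position, on an aromatic carbon of a six-membered aromatic ring with 2 nitrogen, from 2-methylpyridin-3-yl to 1,3-benzothiazol-5-yl gives an at least 250-fold lower number from compound 3 to compound 4 (2.40 log units; beyond the scatter). Until now the low end held only 4-methylphenyl and 4-cyanophenyl, whereas compound 4 shows that a group with hetero atoms in its rings, here nitrogen and sulfur, can sit there too, so hetero atoms alone do not keep the high number of compound 3. Compound 4 gives < 1000 nM, which is a limit and not a number, and its steps from compound 1 and compound 2 cannot be read.

Going by these compounds, whether a plain pyridin-3-yl without the methyl, or a phenyl carrying an amine or a carboxylic acid, would hold the high number here stays open. The order among compound 1, compound 2 and compound 4 also stays open, as all three rest on one value: the limit of < 1000 nM in this assay, at which 3 of the 4 values shown sit.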